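Adding a phenyl ring where compound 3 carries only hydrogen

This account rests on a few compounds, and the source may have more. Where it says the series, first, only, none or still open, it means among the compounds named here.

Measured compounds:
Compound 1, `CCCCCc1cc2nn(-c3ccccc3)cc2cn1`: 2100 nM
Compound 2, `Cc1nc(-c2ccccc2)cc2nn(-c3ccccc3)cc12`: 6300 nM
Compound 3, `c1ccc(-n2cc3cnccc3n2)cc1`: > 100000 nM

The growth read-out here is a functional assay on K562 cells (Homo sapiens) for inhibition, read by fluorescence, with a stated time of 72 h; a lower number here means a stronger inhibitor of growth, a higher number a weaker inhibitor of growth. Compound 3 is the weakest of the three shown by a clear margin. Its result of > 100000 nM is a limit of the assay and not a number, so compound 3 stands at or beyond the ceiling (the limit of > 100000 nM in this assay, at which 1 of the 3 values shown sits). Within the data shown here, the only step that touches compound 3 directly is an at least 47-fold higher number from compound 1 to compound 3 (1.67 log units; beyond the scatter), which shows that taking the pentyl chain off the core removes essentially all of the measurable growth inhibition.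

Compound 4, `c1ccc(-c2cc3nn(-c4ccccc4)cc3cn2)cc1`, is not yet measured. The change from compound 3 to compound 4 is phenyl in place of hydrogen on an aromatic carbon. This places a ring at the very spot where compound 1 carried its pentyl chain, so the reverse of the measured step is the closest guide: a substituent there is expected to bring the number back down by a large amount. Compound 2 also carries a phenyl at that position, together with a methyl elsewhere, and gives 6300 nM, which suggests that a phenyl does not match a pentyl chain exactly.

For compound 4 a strongly lower number than for compound 3 is therefore expected, a step of an at least 20-fold lower number from compound 3 to compound 4 (1.30 log units; beyond the scatter). Compound 4 is estimated at 5000 nM, with a likely range from 1500 nM to 20000 nM.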

Compound 4, concentration for 50% growth inhibition: 3400 nM
For compound 4 the middle estimate is 1.5-fold (0.17 log units) above the measured one; measured number inside the range.
By their numbers in this assay, from the lowest: compounds 1, 4 and 2 (each within the scatter of the next, the first and the last beyond it). At a limit, above all of these: compound 3.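

In this assay a phenyl on the aromatic carbon next to the ring nitrogen gives an at least 29-fold lower number from compound 3 to compound 4 (1.46 log units; beyond the scatter) and so shows that a ring at this position, and not only the pentyl chain of compound 1, goes with measurable growth inhibition. Going by these compounds, the value of compound 3 is a limit of the assay and not a number, so the true size of this step stays unknown: the limit of > 100000 nM in this assay, at which 1 of the 4 values shown sits. Phenyl in place of pentyl gives a 1.6-fold higher number from compound 1 to compound 4 (0.21 log units; within the scatter) and hydrogen in place of methyl gives a 1.9-fold lower number from compound 2 to compound 4 (0.27 log units; within the scatter) and, with both steps within the scatter, these compounds show that having a carbon group at this position matters far more than which of these groups it is.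

The compounds shown leave open how a group of another kind at this position would behave, such as an amine, a carboxylic acid or a chain longer than pentyl. They also leave open whether a group added to the new phenyl ring of compound 4, such as a methoxy group or a fluorine atom, would move the number beyond the scatter.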